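The compounds below may be only part of what the source reports. "The series", "measured", "known", "first", "only" and "open" are said of these compounds alone.

The measured compounds:

Compound 1, `Fc1cccc(-c2nc(Nc3ccccc3)c3cc(F)ccc3n2)c1`: in a functional assay on HT29-AK cells (Homo sapiens) for cytotoxicity, read by MTT assay, with a stated time of 48 h (a lower number here means a stronger inhibitor, a higher number a weaker inhibitor), compound 1 gives 48300 nM.
Compound 2, `COc1ccc(Nc2nc(-c3cccc(F)c3)nc3ccc(F)cc23)cc1`: in this assay compound 2 gives 42300 nM.

Compound 2 stands beside compound 1 in this assay, and the two cannot be told apart: the step of a 1.1-fold lower number from compound 1 to compound 2 (0.06 log units; within the scatter) lies within the scatter. For the measured compounds named here, that single step, which adds a methoxy group to an aromatic carbon, is the only measured comparison available.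

Compound 3, `COc1ccccc1Nc1nc(-c2cccc(F)c2)nc2ccc(F)cc12`, keeps every atom of compound 2 but joins them differently: 2-methoxyphenyl in place of 4-methoxyphenyl on a nitrogen on an aromatic ring. Going by the values given here, no measured step moves the methoxy group from one place on that ring to another, so nothing here tells how this assay answers such a shift. Among the compounds with values here, the one step that is measured, a 1.1-fold lower number from compound 1 to compound 2 (0.06 log units; within the scatter), shows that adding the methoxy group at all made no difference beyond the scatter, which gives no reason to expect the moved methoxy group to matter either.

Compound 3 is therefore expected to land close to compound 2, with an estimated step of a 1.1-fold higher number from compound 2 to compound 3 (0.03 log units; within the scatter). The estimate for compound 3 in this assay is 45000 nM, within a range from 15000 nM to 140000 nM.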

Compound 3, half-maximal inhibitory concentration: > 50000 nM
Compound 3: only a limit was reported; the forecaster's own chance of this, stated with the estimate: 20%; at least 1.1-fold (0.04 log units) between middle value and limit.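

In this assay compound 3 gives > 50000 nM, which is a limit and not a number. Putting 2-methoxyphenyl in place of 4-methoxyphenyl on the nitrogen gives an at least 1.1-fold higher number from compound 2 to compound 3 (0.07 log units; that floor lies within the scatter), and adding the methoxy group to the plain phenyl ring, this time as 2-methoxyphenyl, gives an at least 1.0-fold higher number from compound 1 to compound 3 (0.01 log units; that floor lies within the scatter); both floors lie within the scatter, so neither step shows a real change on its own. What this result adds is a direction: moving the methoxy group on this ring brought no measurable gain in strength, while the true size of the step stays unknown, and it may be small or large, since the reading stops at a limit: the limit of > 50000 nM in this assay, at which 1 of the 3 values shown sits.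

From the compounds shown here alone, all three compounds shown sit at weak numbers, so it remains open whether any group on this ring can bring the number down to a clearly lower level. A hydroxyl group, an amine or a carboxylic acid in place of the methoxy group would test that, and the compounds shown say nothing about how such groups would behave.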